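Extending Compound 3 with a Thiophen-3-yl Group

The source may hold more compounds than are shown below. What is called first, only, known or untested is meant among the compounds shown, and "the series" means these compounds.

Of the compounds shown here, three sharing one core have been tested in an ADME assay on MDCK cells (Canis lupus familiaris) for cytotoxicity, read by microscopy, with a stated time of 48 h; on this read-out lower numbers stand for higher toxicity in this test and higher numbers for lower toxicity in this test. Compound 3 `C[C@H]1[C@H](NCc2cccs2)C[C@H]2C[C@@H]1C2(C)C` gives 25000 nM. Compound 1 `CCCc1csc(CN[C@@H]2C[C@H]3C[C@@H]([C@H]2C)C3(C)C)c1`, which carries a propyl group on an aromatic carbon, gives 12500 nM, and compound 2 `C=Cc1ccsc1CN[C@@H]1C[C@H]2C[C@@H]([C@H]1C)C2(C)C`, which carries a vinyl group on that aromatic carbon, gives 50000 nM. Compound 3 thus stands second highest of the three numbers, but a 2.0-fold higher number from compound 1 to compound 3 (0.30 log units; within the scatter) and a 2.0-fold lower number from compound 2 to compound 3 (0.30 log units; within the scatter) are both within the scatter, so the three substituents at this position cannot be told apart on this read-out.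

Compound 4 `C[C@H]1[C@H](NCc2cc(-c3ccsc3)cs2)C[C@H]2C[C@@H]1C2(C)C` has not yet been measured. Relative to compound 3 the change is thiophen-3-yl in place of hydrogen on an aromatic carbon. Both measured steps touch the same aromatic carbon, exchanging hydrogen for propyl or for vinyl, and neither moved the number beyond the scatter. The thiophen-3-yl group brings in more heavy atoms than either of those, but the three measured compounds give no basis for expecting a shift in one direction or the other. Compound 4 is therefore expected to stay close to compound 3, with a 1.3-fold lower number from compound 3 to compound 4 (0.10 log units; within the scatter) lying within the scatter. The estimate for compound 4 is 20000 nM, with a range from 6000 nM to 50000 nM.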

Compound 4, minimum cytotoxic concentration: 25000 nM
Compound 4: middle estimate off by 1.3-fold (0.10 log units), on the low side; the measured number falls inside the stated range.
By their numbers in this assay, from the lowest: compounds 1, 3, 4 and 2 (each within the scatter of the next, the first and the last beyond it).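

The earlier compounds shown here placed only hydrogen, propyl and vinyl on this aromatic carbon, whereas compound 4 carries a whole five-membered aromatic ring with 5 heavy atoms, 1 sulfur among them, and 1 hydrogen-bond acceptor. In this assay this larger group still leaves the read-out where it was, with no change at the digits printed from compound 3 to compound 4 (within the scatter), and exchanging propyl for the same group gives a 2.0-fold higher number from compound 1 to compound 4 (0.30 log units; within the scatter), so thiophen-3-yl cannot be told apart from either hydrogen or propyl at this position. No measurement shown here accounts for this outcome, and the result is a description of the numbers alone.

The compounds shown leave open whether a group of another kind on this aromatic carbon, such as an amine, a carboxylic acid or a longer chain, would take the number beyond the scatter of compound 3. They also leave open whether a phenyl ring here would behave as thiophen-3-yl does, or whether the same group on a different carbon of the ring would give a comparable number.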